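A few compounds are considered here, and "the series" means these few. Any claim that something is new, unique, unknown or untested is made for them only; others in the source may bear on it.

Compound 1 `CCC(C)(C)Cc1c[nH]c(CCc2ccc(-c3cccc(C)n3)cc2)n1` gives 105 nM in a functional assay on HEK293 cells for agonist activity at Bombesin receptor subtype-3 (Homo sapiens), read by luminescence and calcium flux, with a stated time of 10 min (a lower number here means that less compound is needed, a higher number that more compound is needed for the effect), the second highest of three numbers. Compound 3 `CCC(C)(C)Cc1c[nH]c(CCc2ccc(-c3cccc(N)n3)cc2)n1` gives 37 nM, and compound 2 `CCC(C)(C)Cc1c[nH]c(CCc2ccc(-c3ccncc3)cc2)n1` gives 305 nM. Within the data shown here, two steps touch compound 1: a 2.9-fold higher number from compound 1 to compound 2 (0.46 log units; beyond the scatter), and a 2.8-fold lower number from compound 1 to compound 3 (0.45 log units; beyond the scatter). Compound 4 `CCC(C)(C)Cc1c[nH]c(CCc2ccc(-c3cccnc3C(=O)O)cc2)n1` differs from compound 1 by 2-carboxypyridin-3-yl in place of 6-methylpyridin-2-yl on an aromatic carbon. Among the measured compounds shown here, no measured step shows a carboxy group, so the guide is weak; the only change of the pyridine attachment, from compound 1 to compound 2, raised the number, while the amino group of compound 3 lowered it. A modest rise is therefore expected, a 3.8-fold higher number from compound 1 to compound 4 (0.58 log units; beyond the scatter), beyond the scatter but uncertain in size. Compound 4 is estimated at 400 nM, within 120 nM to 1500 nM.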

Compound 4, half-maximal effective concentration: 1260 nM
The estimate for compound 4 lay 3.2-fold (0.50 log units) below the measured number; the measured number falls inside the stated range.
By their numbers in this assay, from the lowest: compound 3; then compound 1; then compound 2; then compound 4.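

In this assay, among these compounds, 2-carboxypyridin-3-yl is the only group at this aromatic carbon to bring large rises, with a 12-fold higher number from compound 1 to compound 4 (1.08 log units; beyond the scatter) and a 34-fold higher number from compound 3 to compound 4 (1.53 log units; beyond the scatter) as well as the smaller 4.1-fold higher number from compound 2 to compound 4 (0.62 log units; beyond the scatter) in the same direction. Compound 4 therefore has the highest number of the four, and all its steps lie beyond the scatter. No evidence given here accounts for these rises.

The compounds shown do not separate the effect of the carboxy group from that of its ring attachment. A methyl ester or a primary amide in its place could help to tell these apart.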